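The source may hold more compounds than are shown below. What is called first, only, known or untested is meant among the compounds shown, and "the series" means these compounds.

Working notes on the series. In a functional assay on HCT-8 cells (Homo sapiens) for antiproliferative activity, read by sulforhodamine B assay, with a stated time of 3 days (a lower number here means that less compound is needed, a higher number that more compound is needed for the effect), compound 1 (`CCCC1=C(OC)C(CCC)(CCC)C(=O)/C(=C(O)\C=C\c2ccccc2)C1=O`) gives 3.5 uM and compound 2 (`CCCC1(CC=C(C)C)C(=O)C(C(=O)/C=C/c2ccccc2)=C(O)C(CCC)(CCC)C1=O`) gives 6.7 uM on the same cells. For the measured compounds named here, these are the only two numbers so far, and they lie within the usual scatter of each other, so compound 1 cannot be ranked against compound 2.

Compound 3 (`CCCCOC1=C(CCC)C(=O)/C(=C(O)/C=C/c2ccccc2)C(=O)C1(CCC)CCC`) has not yet been measured in this assay and differs from compound 1 by propyl in place of hydrogen on a saturated chain carbon bound to an oxygen on an unsaturated carbon in the form of propyl in place of hydrogen on a saturated chain carbon bound to an oxygen on an unsaturated carbon. The same difference reads as methoxy to butoxy. Going by the values given here, no measured pair shows a change of this kind, so its size cannot be read from the data.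

The expectation therefore starts from compound 1 at 3.5 uM as the reference, with no step beyond the scatter foreseen and no firm direction. The expected change is a 1.1-fold higher number from compound 1 to compound 3 (0.06 log units; within the scatter) and stays within the usual scatter. In this assay compound 3 is estimated at 4 uM with an expected range from 1.8 uM to 9 uM for the coming measurement.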

Compound 3, concentration for half-maximal effect: 8.7 uM
Beside the measured number, compound 3's estimate is 2.2-fold (0.34 log units) below it; the measured number falls inside the stated range.
By their numbers in this assay, from the lowest: compounds 1, 2 and 3 (each within the scatter of the next, the first and the last beyond it).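

In this assay, for the compounds shown here, the change from methoxy to butoxy gives a 2.5-fold higher number from compound 1 to compound 3 (0.40 log units; beyond the scatter), the first step that can be read at all and one that lies beyond the scatter, though it is modest. It shows that the group on this oxygen is not indifferent: adding propyl on a saturated chain carbon bound to an oxygen on an unsaturated carbon moves the number upward, so the longer ether here comes with a higher concentration for the same effect, while the effect itself remains measurable. The data in hand hold nothing that accounts for the size or the direction of this step.

With only methoxy and butoxy at this place, two points cannot show whether the number climbs steadily with chain length or changes abruptly, and an ethoxy group, a longer chain such as hexyloxy, or a chain ending in an amine or a carboxylic acid could each separate these readings. From the compounds shown here alone, it also stays open whether the same change would give a step of similar size on a core carrying other groups elsewhere.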